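Does a Second Chloro Lower the Number for Compound 4?

The compounds below may be only part of what the source reports. "The series", "measured", "known", "first", "only" and "open" are said of these compounds alone.

Three compounds have been measured in a functional assay on EKVX cells (Homo sapiens) for cytotoxicity, read by sulforhodamine B assay, with a stated time of 48 h; on this read-out higher numbers stand for weaker inhibition of growth and lower numbers for stronger inhibition of growth:

compound 1 `ClCc1cccc(Cn2cnc3nc(Cl)nc(Cl)c32)c1`: 930 nM
compound 2 `ClCc1ccc(Cn2cnc3ncnc(Cl)c32)cc1`: 2230 nM
compound 3 `ClCc1cccc(Cn2cnc3ncnc(Cl)c32)c1`: 13800 nM

Compound 2 holds the second highest of these three numbers in this assay. Its nearest neighbour is compound 1, which gives a lower number, and its furthest is compound 3, which gives a higher one; both gaps lie beyond the usual scatter of repeated measurements.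

Compound 4 `ClCc1ccc(Cn2cnc3nc(Cl)nc(Cl)c32)cc1` is the unmeasured partner of compound 2. It differs from compound 2 by chloro in place of hydrogen on an aromatic carbon.

Within the data shown here, one measured step bears directly on this change, and it runs in the opposite direction: a 15-fold higher number from compound 1 to compound 3 (1.17 log units; beyond the scatter). That step was large and well beyond the scatter. The change from compound 2 to compound 4 puts the chloro back in the same place on the shared core, so the number for compound 4 is expected to fall substantially, an 8.9-fold lower number from compound 2 to compound 4 (0.95 log units; beyond the scatter). Among the measured compounds shown here, the single supporting step comes from a pair with a different substitution pattern on the benzyl ring, so the range is kept wide. Compound 4 is estimated at 250 nM, between 70 nM and 900 nM.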

Compound 4, concentration for 50% growth inhibition: 1900 nM
Compound 4: middle estimate off by 7.6-fold (0.88 log units), on the low side; measured number outside the range, above it.
By their numbers in this assay, from the lowest: compound 1; then compounds 4 and 2 (each within the scatter of the next); then compound 3.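

In this assay, chloro in place of hydrogen on the aromatic carbon between two ring nitrogen atoms does not have one fixed size of effect, and here the step is a 1.2-fold lower number from compound 2 to compound 4 (0.07 log units; within the scatter). Among these compounds, on the core of compound 2, this position therefore tolerates either hydrogen or chloro with no difference that can be told from the scatter, whereas the earlier compounds had offered only the large step on the core of compound 1. The size of this change thus depends on the core that carries it, and the single earlier step does not transfer from one core to the other: the same change on two cores in this assay, a 15-fold higher number (1.17 log units; beyond the scatter) from compound 1 to compound 3 and a 1.2-fold higher number (0.07 log units; within the scatter) from compound 4 to compound 2, 13-fold (1.10 log units) apart, beyond the scatter of two such steps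

The compounds shown carry only hydrogen or chloro at this position, so it remains open how an amine or a methoxy group there would read on either core. They also give no account of why the two cores part ways, and they say nothing about this change outside this assay.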